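Esterification of a pyrimidinone acid series in a rat model

The source may report more compounds than this note shows. Statements on the series, on what has been measured and on what is new or still open speak of the compounds shown alone.

Measured compounds:
Compound 1 `COc1ccc(-c2ncc(C(=O)O)c(=O)[nH]2)cc1`, > 5 mg/kg
Compound 2 `CCOC(=O)c1cnc(-c2ccc(OC)cc2)[nH]c1=O`, 30 mg/kg
Compound 3 `CCOc1ccccc1-c1ncc(C(=O)O)c(=O)n1C`, > 50 mg/kg

In a functional assay on the whole organism (strain Sprague-Dawley) for inhibition, with Rattus norvegicus as the target, with a stated time of 10 min (a higher number here means that more compound is needed for the effect, a lower number that less compound is needed), compound 1 gives > 5 mg/kg, which is a limit of the assay and not a number. In this assay compound 2 gives 30 mg/kg. The change from compound 1 to compound 2 is ethyl in place of hydrogen on an oxygen next to a carbonyl group. The step that the limit leaves unreadable from compound 1 to compound 2 cannot be read because compound 1 sits at the limit of > 5 mg/kg in this assay, at which 1 of the 3 values shown sits.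

Compound 3 gives > 50 mg/kg in this assay, again a limit rather than a number. The difference between the core of compound 1 and the core of compound 3 is not broken down here.

Compound 4 `CCOC(=O)c1cnc(-c2ccccc2OCC)n(C)c1=O` has not yet been measured in this assay. It differs from compound 3 by ethyl in place of hydrogen on an oxygen next to a carbonyl group, the same change as from compound 1 to compound 2. Since the earlier step is unreadable, and compound 3 rests at the limit of > 50 mg/kg in this assay, at which 1 of the 3 values shown sits, the size of the step from compound 3 to compound 4 cannot be taken from the measured pairs. Going by the values given here, compound 2 is the only compound here with the ester that yields a number, so the expectation for compound 4 leans on that value while allowing for the unread limit of compound 3. Compound 4 is expected to give about 40 mg/kg, between 15 mg/kg and 150 mg/kg, and the expected step is an at least 1.2-fold lower number from compound 3 to compound 4 (0.09 log units; that floor lies within the scatter).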

Compound 4, dose for 50% inhibition: > 40 mg/kg
Compound 4: a limit, no number (the forecaster's own chance of this, stated with the estimate: 55%); the middle value lies on the limit itself.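

In this assay compound 4 gives > 40 mg/kg, which is a limit of the assay and not a number. Compound 3 also stands at a limit, and the step between compound 3 and compound 4 cannot be read. The compounds shown leave open how large the change from carboxy to ethoxycarbonyl is: neither compound 1 and compound 2 nor compound 3 and compound 4 have numbers at both ends.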